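This account rests on a few compounds, and the source may have more. Where it says the series, first, only, none or still open, it means among the compounds named here.

Measured in a functional assay on HeLa cells (Homo sapiens) for inhibition, read by CCK-8 assay, with a stated time of 48 h; a lower number here means a stronger inhibitor, a higher number a weaker inhibitor:

- Compound 1 `O=C(NCCNS(=O)(=O)c1ccc(-c2ccccc2O[C@H]2CC[C@H](O)CC2)s1)Nc1cc(C(F)(F)F)cc(C(F)(F)F)c1`: > 20000 nM (a limit)
- Compound 2 `O=S(=O)(NCCNC(=S)Nc1cc(C(F)(F)F)cc(C(F)(F)F)c1)c1sccc1-c1ccccc1Oc1ccc(O)c(O)c1`: > 50000 nM (a limit)

Compound 1 has no exact value and stands only at the limit > 20000 nM. Compound 3 `O=C(NCCNS(=O)(=O)c1ccc(-c2ccccc2Oc2ccc(O)c(O)c2)s1)Nc1cc(C(F)(F)F)cc(C(F)(F)F)c1` keeps the core of compound 1 but has 3,4-dihydroxyphenyl in place of 4-hydroxycyclohexyl on an oxygen on an aromatic ring. Among the compounds with values here, no pair of measured compounds shows what this change does in this assay, so the expectation has little to rest on. The nearest guide is compound 2, which also carries 3,4-dihydroxyphenyl and stands at the limit > 50000 nM. A clear gain in strength is therefore not expected, and another limit is quite possible. The expected change is a step that the limit leaves unreadable from compound 1 to compound 3, which would mean no real move beyond the scatter. Compound 3 is estimated at 25000 nM, with an expected range of 7000 nM to 60000 nM.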

Compound 3, half-maximal inhibitory concentration: > 20000 nM
Compound 3: a limit, no number (the forecaster's own chance of this, stated with the estimate: 55%); the middle value does not contradict the limit.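

Compound 1 and compound 3 both stand only at a limit in this assay, and the step between them cannot be read. The compounds shown leave open how strongly each one inhibits, and whether 3,4-dihydroxyphenyl in place of 4-hydroxycyclohexyl changes that strength at all.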